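From 4-methoxyphenyl to 3,4-dimethoxyphenyl in compound 3

A few compounds are considered here, and "the series" means these few. Any claim that something is new, unique, unknown or untested is made for them only; others in the source may bear on it.

Measured in a toxicity assay on WI-38 cells (Homo sapiens) for cytotoxicity, read by MTT assay, with a stated time of 48 h; on this read-out higher numbers stand for weaker inhibition and lower numbers for stronger inhibition:
Compound 1 `COc1cc(/C=C/C(=O)c2cc3cccc(OC)c3oc2=O)cc(OC)c1OC` gives 9550 nM
Compound 2 `COc1ccc(/C=C(\C#N)C(=O)N/N=C(\C)c2cc3cccc(OC)c3oc2=O)cc1` gives 48400 nM

Compound 2 holds the higher of the two numbers, and compound 1 lies lower by more than the usual scatter. Compound 3 `COc1ccc(/C=C(\C#N)C(=O)N/N=C(\C)c2cc3cccc(OC)c3oc2=O)cc1OC` awaits measurement. It differs from compound 2 by methoxy in place of hydrogen on an aromatic carbon. For the measured compounds named here, no measured pair shows this change, so the expectation in this assay is no step beyond the scatter, with at most a slight drift toward lower numbers. The expected change is a 1.2-fold lower number from compound 2 to compound 3 (0.08 log units; within the scatter). For compound 3 the estimated value is 40000 nM, with an expected range from 15000 nM to 100000 nM.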

Compound 3, half-maximal inhibitory concentration: 3300 nM
For compound 3 the middle estimate is 12-fold (1.08 log units) above the measured one; measured number below the stated range.
By their numbers in this assay, from the lowest: compound 3; then compound 1; then compound 2.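

The step to 3,4-dimethoxyphenyl in this assay gives a 15-fold lower number from compound 2 to compound 3 (1.17 log units; beyond the scatter), so this position on the ring is not silent: a methoxy group ortho to a methoxy group and meta to a large group moves the number markedly. For the compounds shown here, only this one pair shows the change, and nothing here accounts for the size of the step. On these data alone, it stays open whether a hydroxyl, an amine or a chlorine at this position would move the number as far, and whether an ethoxy group would do the same.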